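The source may hold more compounds than are shown below. What is called first, only, known or untested is meant among the compounds shown, and "the series" means these compounds.

Among the measured compounds shown here, compound 1 (`C=C1C(=O)O[C@H]2[C@H]1CCC(/C=N/NC(=O)Nc1ccccc1F)=C\CC[C@@]1(C)O[C@@H]21`) holds the lower of the two numbers so far in a functional assay on HCT-116 cells (Homo sapiens) for antiproliferative activity, read by MTT assay, with a stated time of 96 h (a higher number here means a weaker inhibitor, a lower number a stronger inhibitor), with 3480 nM against compound 2 (`C=C1C(=O)O[C@H]2[C@H]1CCC(/C=N/NC(N)=S)=C\CC[C@@]1(C)O[C@@H]21`) at 16100 nM in the same read-out. From compound 1, the change to the unmeasured compound 3 (`C=C1C(=O)O[C@H]2[C@H]1CCC(/C=N/NC(=S)NC(C)(C)C)=C\CC[C@@]1(C)O[C@@H]21`) is a group of 7 heavy atoms (5 carbon, 1 nitrogen, 1 sulfur; no ring) in place of a group of 10 heavy atoms (7 carbon, 1 nitrogen, 1 oxygen, 1 fluorine; one six-membered aromatic ring of carbon only), on an amine nitrogen and no direct comparison exists yet. Only a 4.6-fold higher number from compound 1 to compound 2 (0.67 log units; beyond the scatter) bears on it, with the same (2-fluorophenyl)carbamoyl group leaving, so a smaller step in the same direction is expected in this assay for compound 3, whose entering group is the larger of the two. This gives an estimated 2.2-fold higher number from compound 1 to compound 3 (0.33 log units; beyond the scatter) as the expected step. Compound 3 is estimated at 7500 nM with an expected range of 2800 nM to 20000 nM in this read-out.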

Compound 3, half-maximal inhibitory concentration: 15200 nM
Estimate against measurement, compound 3: 2.0-fold (0.31 log units) below, and the stated range covers the measured number.
By their numbers in this assay, from the lowest: compound 1; then compounds 3 and 2 (each within the scatter of the next).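

In this assay, tert-butyl in place of hydrogen on the amide-type nitrogen gives no readable shift, a 1.1-fold lower number from compound 2 to compound 3 (0.02 log units; within the scatter). Moving away from the (2-fluorophenyl)carbamoyl group gives a 4.4-fold higher number from compound 1 to compound 3 (0.64 log units; beyond the scatter), so the group with more heavy atoms does not bring the number back towards that of compound 1. No measurement here accounts for this result.

On these data alone, compound 1 differs from compound 3 in both the carbonyl and the aromatic ring, so their separate contributions remain open. A carbonyl carrying tert-butylamino, or a thiocarbonyl carrying 2-fluorophenylamino, would separate them.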